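The source may report more compounds than this note shows. Statements on the series, on what has been measured and on what is new or still open speak of the compounds shown alone.

Measured so far:
Compound 1, `COCc1cc(CN2CCCC2)c(O)c2ncccc12`, 1350 nM.
Compound 2, `CCOCc1cc(CN2CCCC2)c(O)c2ncccc12`, 912 nM.
Compound 3, `CCOCc1cc(CN2CCC(C)CC2)c(O)c2ncccc12`, 468 nM.

All three were tested in a functional assay on MES-SA/Dx5 cells (Homo sapiens) for inhibition, with a stated time of 72 h; a higher number here means a weaker inhibitor, a lower number a stronger inhibitor. Compound 2 differs from compound 1 by methyl in place of hydrogen on a saturated chain carbon bound to an oxygen on a saturated carbon; that change gave a 1.5-fold lower number from compound 1 to compound 2 (0.17 log units; within the scatter). Compound 3 differs from compound 2 by a different change at another position, and that step gave a 1.9-fold lower number from compound 2 to compound 3 (0.29 log units; within the scatter). Compound 3 thus carries the lowest number of the three, and its gap to compound 1 is beyond the scatter, while its gap to compound 2 is not.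

The unmeasured compound 4 is `CC1CCN(Cc2cc(COC(C)C)c3cccnc3c2O)CC1`. It differs from compound 3 by methyl in place of hydrogen on a saturated chain carbon bound to an oxygen on a saturated carbon and a saturated chain carbon. Within the data shown here, this is the same kind of change as the one from compound 1 to compound 2, though the surroundings differ: in compound 4 the carbon that takes the methyl is bound to an oxygen on a saturated carbon and a saturated chain carbon, whereas in compound 2 it is bound to an oxygen on a saturated carbon only. The difference between the core of compound 1 and the core of compound 3 is not broken down here.

Because the earlier instance gave a 1.5-fold lower number from compound 1 to compound 2 (0.17 log units; within the scatter), a step of similar, small size is expected for compound 4, namely a 1.4-fold lower number from compound 3 to compound 4 (0.14 log units; within the scatter). Compound 4 is therefore estimated at 340 nM, with a likely range from 150 nM to 800 nM.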

Compound 4, half-maximal inhibitory concentration: 355 nM
Compound 4: middle estimate off by 1.0-fold (0.02 log units), on the low side; low and high end bracket the measured number.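

In this assay, methyl in place of hydrogen on a saturated chain carbon bound to an oxygen on a saturated carbon and a saturated chain carbon, which turns ethoxymethyl into isopropoxymethyl, gave a 1.3-fold lower number from compound 3 to compound 4 (0.12 log units; within the scatter) and so no clear change on its own. Set side by side, this step and the earlier one on the core of compound 1 cannot be told apart, so in this small series the change carried from one core to the other without a visible difference: the same change on two cores in this assay, a 1.5-fold lower number (0.17 log units; within the scatter) from compound 1 to compound 2 and a 1.3-fold lower number (0.12 log units; within the scatter) from compound 3 to compound 4, 1.1-fold (0.05 log units) apart, within the scatter of two such steps. This does not show that the added methyl itself shifts the number, since each step alone stays within the scatter, and two pairs, with the methyl landing on differently substituted carbons, give no rule for other cores.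

From the compounds shown here alone, what a longer chain, such as butoxymethyl, or a ring-bearing ether, such as cyclopropylmethoxymethyl, would do in the same place remains open. Going by these compounds, it is also open whether the step would read the same with an amine such as morpholine in place of pyrrolidin-1-yl or 4-methylpiperidin-1-yl.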